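The source may report more compounds than this note shows. Statements on the series, on what has been measured and on what is new or still open speak of the compounds shown alone.

Compound 1 `O=C(O)CCCC/C=C(\c1cccnc1)c1cccc(Br)c1` is one of two compounds with a number in an assay (Equus caballus) for inhibition of Thromboxane-A synthase (Homo sapiens), using microsomes; on this read-out higher numbers stand for weaker inhibition and lower numbers for stronger inhibition. In this assay compound 1 gives 180 nM, the highest of the two numbers. Its nearest neighbour is compound 2 `COC(=O)CCCC/C=C(\c1ccccc1)c1cccnc1`, which in this assay gives 100 nM; the two values lie within the usual scatter of each other, so nothing separates them. Compound 3 `Cc1ccc(/C(=C/CCCCC(=O)O)c2cccnc2)cc1` has not yet been measured in this assay. It differs from compound 1 in one place: 4-methylphenyl in place of 3-bromophenyl on a double-bonded chain carbon bound to an aromatic carbon and a double-bonded chain carbon. Both compounds keep the shared core of compound 1. For the measured compounds named here, no measured pair here connects a change of this kind to a shift in this assay, and the two measured values themselves show no separation. The step of a 1.2-fold lower number from compound 1 to compound 3 (0.08 log units; within the scatter) is therefore expected to stay within the scatter, in no particular direction. Compound 3 is estimated to give 150 nM in this assay, within a range from 50 nM to 450 nM.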

Compound 3, half-maximal inhibitory concentration: 85 nM
Compound 3: the middle estimate sits 1.8-fold (0.25 log units) above what was measured; measured number inside the range.
By their numbers in this assay, from the lowest: compounds 3, 2 and 1 (each within the scatter of the next, the first and the last beyond it).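

For the compounds shown here, putting 4-methylphenyl in place of 3-bromophenyl on a double-bonded chain carbon bound to an aromatic carbon and a double-bonded chain carbon gives, in this assay, a 2.1-fold lower number from compound 1 to compound 3 (0.33 log units; beyond the scatter), the first step beyond the scatter tied to a change at this place. The place therefore responds to a change of group, although the step is modest and both groups have the same count of heavy atoms and one six-membered aromatic ring of carbon only. Nothing at hand accounts for the direction or size of this step.

This single step cannot separate the loss of bromine from the gain of methyl, nor either of these from the different location of the group on the ring. On these data alone, how a chlorine atom or a methoxy group would behave at this place also remains open.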